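Swapping a Phenylethenyl Arm for a Bromophenyl Ring

The source may report more compounds than this note shows. Statements on the series, on what has been measured and on what is new or still open speak of the compounds shown alone.

Compound 1 `O=C(COc1cccc2ccccc12)N/N=C/C=C/c1ccccc1` stands second highest of three in a physicochemical assay for lipophilicity, measured as octanol-water partition (a higher number here means a more lipophilic compound, a lower number a more polar compound), where compound 1 gives 4.43. Its nearest neighbour is compound 3 `O=C(COc1cccc2ccccc12)N/N=C/c1c(O)ccc2ccccc12`, which gives 4.74, a gap beyond the scatter, and the furthest is compound 2 `C/C(=N\NC(=O)COc1cccc2ccccc12)c1ccc([N+](=O)[O-])cc1`, which gives 3.37. Compound 4 `O=C(COc1cccc2ccccc12)N/N=C/c1cccc(Br)c1` keeps the shared core of compound 1 but carries 3-bromophenyl in place of 2-phenylethenyl on a carbon with a double bond to nitrogen. For the measured compounds named here, no measured pair in this set makes exactly that change. One aromatic ring with a double bond outside it gives way to one aromatic ring carrying bromine. The step in this assay is expected to be small, within the scatter, with no clear direction. Compound 4 is therefore estimated at 4.5, within a range from 4.1 to 4.9. That estimate means an expected step of a number 0.07 log units higher from compound 1 to compound 4 (within the scatter).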

Compound 4, partition coefficient: 4.81
Compound 4: the middle estimate sits 0.31 log units below what was measured; the measured number falls inside the stated range.
By their numbers in this assay, from the lowest: compound 2; then compound 1; then compounds 3 and 4 (each within the scatter of the next).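

In this assay, 3-bromophenyl in place of 2-phenylethenyl on a carbon with a double bond to nitrogen gives a number 0.38 log units higher from compound 1 to compound 4 (beyond the scatter). For the compounds shown here, this is the first comparison here that changes one place only, so it shows that this place can move the number beyond the scatter while the shared core stays the same. Nothing available explains the step.

Still open, going by these compounds, is how much of the step goes with the bromine and how much with the departing double bond, which a plain phenyl group at this place would help separate. So is the result with an amine or a carboxylic acid there.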